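The source may hold more compounds than are shown below. What is called first, only, known or untested is meant among the compounds shown, and "the series" means these compounds.

Compound 1 `C/N=C(/NC#N)NCCCCCn1nc(-c2ccccc2)c(C)cc1=O`, compound 2 `CC/N=C(/NC#N)NCCCCn1nc(-c2ccccc2)c(C)cc1=O` and compound 3 `CC/N=C(/NC#N)NCCCCn1nc(-c2ccccc2)cc(C)c1=O` have each been run in a functional assay on the whole organism with Rattus norvegicus as the target, at a dose of 100 mg/kg; on this read-out higher numbers stand for more inhibition at the one dose given (going by the name of the read-out) and lower numbers for less inhibition. In this assay compound 1 gives 28.5%, compound 2 gives 38.8% and compound 3 gives 42.5%. The values of compound 2 and compound 3 lie within the scatter of each other; the difference between the cores of compound 2 and compound 3 is not broken down here. On the core of compound 2, the change a group of 8 heavy atoms (4 carbon, 4 nitrogen; no ring) in place of a group of 8 heavy atoms (4 carbon, 4 nitrogen; no ring), on a saturated chain carbon, four bonds along the chain from an aromatic nitrogen produced a number 10.3 percentage points lower from compound 2 to compound 1 (beyond the scatter), a modest loss but beyond the scatter. Within the data shown here, compound 4 `C/N=C(/NC#N)NCCCCCn1nc(-c2ccccc2)cc(C)c1=O` carries the same change on the core of compound 3, (a group of 8 heavy atoms (4 carbon, 4 nitrogen; no ring) in place of a group of 8 heavy atoms (4 carbon, 4 nitrogen; no ring), on a saturated chain carbon, four bonds along the chain from an aromatic nitrogen), at the same place, so the measured step serves as the only guide. In this assay the estimated step is a number 10.5 percentage points lower from compound 3 to compound 4 (beyond the scatter) because of a number 10.3 percentage points lower from compound 2 to compound 1 (beyond the scatter). This rests on a single pair; the core swap itself has not shown a counted effect, so the transfer is assumed rather than tested. Compound 4 is expected to give 32% in this assay, with a likely range of 20% to 44%.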

Compound 4, a percentage reported as inhibition, in the whole organism at one dose (the size of the read-out at that dose, not a potency): 33.8%
Beside the measured number, compound 4's estimate is 1.8 percentage points below it; low and high end bracket the measured number.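

In this assay the change on the second core gives a number 8.7 percentage points lower from compound 3 to compound 4 (within the scatter), so this step taken alone does not separate the two compounds. Set beside the earlier step, it shows that the change carries over between these two cores with no difference in size that can be told from scatter: the same change on two cores in this assay, a number 10.3 percentage points lower (beyond the scatter) from compound 2 to compound 1 and a number 8.7 percentage points lower (within the scatter) from compound 3 to compound 4, 1.6 percentage points apart, within the scatter of two such steps. This supports transfer only for these two pairs and this single-dose, whole-organism read-out; it gives no measure of potency, offers no explanation for the steps, and cannot be extended to other cores.

On these data alone, it remains open whether the same step would hold with a longer chain at this place, or with an amine or a carboxylic acid in place of the nitrile. Also open, as far as these compounds go, is whether the two groups exchanged here would keep the same relation at other doses or on a core with a different group in place of the methyl.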